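Lengthening a Saturated Chain and Tolerated Concentration in Cells

The compounds below may be only part of what the source reports. "The series", "measured", "known", "first", "only" and "open" are said of these compounds alone.

This account concerns three compounds that share one core and differ only in the length of a saturated chain attached to it: compound 1 `CCCCCc1cc2cn([C@H]3C[C@H](O)[C@@H](CO)O3)c(=O)nc2o1`, compound 2 `CCCCCCc1cc2cn([C@H]3C[C@H](O)[C@@H](CO)O3)c(=O)nc2o1` and compound 3 `CCCCCCCc1cc2cn([C@H]3C[C@H](O)[C@@H](CO)O3)c(=O)nc2o1`. In a functional assay on HEL cells (Homo sapiens) for cytotoxicity (a higher number here means that more compound is tolerated, a lower number that less compound is tolerated), compound 1 reaches only a limit of the assay, > 50000 nM. In this assay compound 2 likewise reaches only a limit of the assay, > 200000 nM. Because both values are limits, the step that the two limits leave unreadable from compound 1 to compound 2 cannot be read as a number. Compound 2 stands at the limit of > 200000 nM in this assay, at which 1 of the 2 values shown sits. Compound 1 stands at the limit of > 50000 nM in this assay, at which 1 of the 2 values shown sits. The change from compound 2 to compound 3 is methyl in place of hydrogen on a saturated chain carbon, six bonds along the chain from an aromatic carbon. Going by the values given here, the only measured step of the same kind, a step that the two limits leave unreadable from compound 1 to compound 2, has no readable size, so no direction can be taken from it; with both measured compounds sitting at limits, a further limit is the most likely outcome in this assay. Compound 3 is therefore expected to show a number no higher from compound 2 to compound 3 (the limit leaves the size open). The estimated value of compound 3 is 200000 nM, expected to fall between 50000 nM and 500000 nM.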

Compound 3, half-maximal cytotoxic concentration: > 50000 nM
Compound 3 gave a limit, no number (the forecaster's own chance of this, stated with the estimate: 85%); the middle value lies beyond the limit too.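

Compound 3 gives > 50000 nM in this assay, which is a limit of the assay and not a number. With compound 1, compound 2 and compound 3 all at limits, none of the steps among them can be read. The compounds shown leave open what concentration of each is actually tolerated in this assay, and whether lengthening the saturated chain changes it at all.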